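The compounds below may be only part of what the source reports. "The series", "measured", "known", "first", "only" and "open" are said of these compounds alone.

Compound 1, `CC(C)(C)OC(=O)NCCC[C@@H]1N=C2C[C@@H]3C[C@@H](C3(C)C)[C@]2(C)OC1=O`. In an ADME assay on MCF-10A cells (Homo sapiens) for antiproliferative activity, read by sulforhodamine B assay, with a stated time of 48 h (a lower number here means a stronger inhibitor, a higher number a weaker inhibitor), compound 1 gives > 1200000 nM, which is a limit of the assay and not a number.
Compound 2, `CC(C)(C)OC(=O)NCCCC[C@H]1N=C2C[C@H]3C[C@H](C3(C)C)[C@@]2(C)OC1=O`. Compound 2 gives > 1300000 nM, also a limit.
Compound 3, `CC1(C)[C@H]2CC[C@]1(C)[C@H]1OC(=O)CN=C21`. Compound 3 gives > 900000 nM, again a limit.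

Compound 2 therefore cannot be placed on a scale of numbers: its own value and the two others are all limits, and none separates one compound from another. Compound 4, `CC(C)(C)OC(=O)NCCC[C@H]1N=C2C[C@H]3C[C@H](C3(C)C)[C@@]2(C)OC1=O`, differs from compound 2 by one change: (tert-butoxycarbonyl)amino in place of ((tert-butoxycarbonyl)amino)methyl on a saturated chain carbon, three bonds along the chain from a saturated ring carbon. Going by the values given here, no measured step links these two compounds, so the expectation rests on the three limits alone. With every measured neighbour sitting at a limit, no step beyond the scatter is expected in this assay in either direction. Compound 4 is expected to give about 1300000 nM, between 400000 nM and 4000000 nM, most likely reported again as a limit. The step this estimate implies is a number no higher from compound 2 to compound 4 (the limit leaves the size open), expected to be none beyond the scatter.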

Compound 4, half-maximal inhibitory concentration: > 1500000 nM
Compound 4: a limit, no number (the forecaster's own chance of this, stated with the estimate: 85%); at least 1.1-fold (0.06 log units) between middle value and limit.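

Compound 1, compound 2 and compound 4 all sit at limits in this assay, so neither step to compound 4 can be read. The compounds shown leave open whether chain length or mirror-image configuration changes activity at all.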